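The compounds below may be only part of what the source reports. "The series", "measured", "known", "first", "only" and "open" are said of these compounds alone.

The measured compounds and their values:

- compound 1, `COc1ccc(-c2cn3ccnc3c(-c3ccc4ncn(C5CCCCC5)c4c3)n2)cc1`: 82.8%
- compound 2, `O=Cc1ccc(-c2cn3ccnc3c(-c3ccc4ncn(C5CCCCC5)c4c3)n2)cc1`: 58.7%
- compound 3, `Fc1ccc(-c2cn3ccnc3c(-c3ccc4ncn(C5CCCCC5)c4c3)n2)cc1`: 25.2%

All three share one core and differ only in the group carried on the outer aromatic ring. In a functional assay on MOLT-4 cells (Homo sapiens) for inhibition, read by sulforhodamine B assay, with a stated time of 48 h, tested at 10 uM (a lower number here means less inhibition, a higher number more inhibition at the concentration tested (going by the name of the read-out)), compound 2 stands second highest of the three: compound 1 is higher, by a number 24.1 percentage points lower from compound 1 to compound 2 (beyond the scatter), while compound 3 lies well below, by a number 33.5 percentage points lower from compound 2 to compound 3 (beyond the scatter). Compound 4, `CC(=O)c1ccc(-c2cn3ccnc3c(-c3ccc4ncn(C5CCCCC5)c4c3)n2)cc1`, is not yet measured. It differs from compound 2 at one spot only: methyl in place of hydrogen on a carbonyl carbon, so the formyl becomes an acetyl.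

Among the compounds with values here, no measured step swaps formyl for acetyl. The two steps that touch the same place, a number 24.1 percentage points lower from compound 1 to compound 2 (beyond the scatter) and a number 33.5 percentage points lower from compound 2 to compound 3 (beyond the scatter), show that exchanging the whole group can move the number by a lot, but each of those exchanges replaces one kind of group by a quite different one. Adding a methyl onto an existing carbonyl is a smaller change than either, and nothing measured here speaks for a movement in one direction rather than the other. The expected step from compound 2 to compound 4 is therefore a number 0.7 percentage points lower from compound 2 to compound 4 (within the scatter), a change not expected to exceed the scatter. Compound 4 is estimated at 58%, with a range from 35% to 80%.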

Compound 4, a percentage reported as inhibition, at one concentration (the size of the read-out at that concentration, not a potency): 14.3%
Compound 4: middle estimate off by 43.7 percentage points, on the high side; the whole stated range lies above it.
By their numbers in this assay, from the lowest: compound 4; then compound 3; then compound 2; then compound 1.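

In this assay the added methyl alone gives a number 44.4 percentage points lower from compound 2 to compound 4 (beyond the scatter) so a change of one carbon on the carbonyl can move the number as far as exchanging the whole group on the outer ring. The acetyl group also falls short of fluoro, with a number 10.9 percentage points lower from compound 3 to compound 4 (beyond the scatter) and much further short of methoxy, with a number 68.5 percentage points lower from compound 1 to compound 4 (beyond the scatter) which makes compound 4 the lowest of the four, while compound 2, which also carries a carbonyl at this spot, stays in the middle, so having a carbonyl there does not by itself set the level of inhibition. Nothing available here explains why this small addition has such a large effect.

The compounds shown leave open whether the fall belongs to the methyl in particular or would also follow from a longer chain on the carbonyl, as in propanoyl, or from an amide or a carboxylic acid in the same place. They also leave open how a group without a carbonyl, such as hydroxymethyl or an amine, would compare with the methoxy of compound 1.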